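Quinolinyl for Fluorinated Ester Aryl on a Shared Core

The source may report more compounds than this note shows. Statements on the series, on what has been measured and on what is new or still open speak of the compounds shown alone.

This account follows four compounds built around a fused bicyclic core carrying a branched side chain. Compound 1 `COC(=O)c1ccc(-c2cnc3ncn(C(C)c4c(F)cc5ncccc5c4F)c3n2)cc1F` is measured in a functional assay on NCI-H1993 cells (Homo sapiens) for inhibition, read by CCK-8 assay, with a stated time of 72 h (on this read-out lower numbers stand for stronger inhibition and higher numbers for weaker inhibition), and gives 29.4 nM. Compound 3 `CC(c1c(F)cc2ncccc2c1F)n1cnc2ncc(-c3cnc4ccccc4c3)nc21` gives 46.1 nM in this assay. Between them stands one change, (quinolin-3-yl in place of 3-fluoro-4-(methoxycarbonyl)phenyl on an aromatic carbon), which gives a 1.6-fold higher number from compound 1 to compound 3 (0.20 log units; within the scatter). Compound 2 `COC(=O)c1ccc(-c2cnc3ncn(C(C)c4ccc5ncccc5c4C)c3n2)cc1F` gives "not determined" (no result reported) in this assay, so no number stands for it, and the difference between the core of compound 1 and the core of compound 2 is not broken down here. Compound 4 `Cc1c(C(C)n2cnc3ncc(-c4cnc5ccccc5c4)nc32)ccc2ncccc12` is not yet measured in this assay. It arises from compound 2 by quinolin-3-yl in place of 3-fluoro-4-(methoxycarbonyl)phenyl on an aromatic carbon, the same change as that from compound 1 to compound 3. Because compound 3 gives 46.1 nM after a step of a 1.6-fold higher number from compound 1 to compound 3 (0.20 log units; within the scatter), a value of comparable size is expected for compound 4, at about 50 nM, likely between 15 nM and 170 nM, with the unmeasured compound 2 leaving the range wide.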

Compound 4, half-maximal inhibitory concentration: 450 nM
Compound 4: middle estimate off by 9.0-fold (0.95 log units), on the low side; measured number above the stated range.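

In this assay, among these compounds, compound 2 has no single number, so no new step to compound 4 can be read. The compounds shown leave open what the difference in core contributes, and no evidence shown bears on the result for compound 4.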